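The source may report more compounds than this note shows. Statements on the series, on what has been measured and on what is new or still open speak of the compounds shown alone.

In an assay on a protein complex for inhibition of CDK8/Cyclin C (Homo sapiens), with a stated time of 1 h (on this read-out lower numbers stand for stronger inhibition and higher numbers for weaker inhibition), compound 2 `O=C(O)/C=C/c1ccncc1-c1ccc2ccccc2c1` gives 5 nM, the lowest of the two numbers measured here. Among the measured compounds shown here, its only measured neighbour, compound 1 `CN1CCN(C(=O)/C=C/c2ccncc2-c2ccc3ccccc3c2)CC1`, gives 43.6 nM. Compound 3 `COC(=O)/C=C/c1ccncc1-c1ccc2ccccc2c1` differs from compound 2 by methyl in place of hydrogen on an oxygen next to a carbonyl group. For the measured compounds named here, no measured pair shows this exact change; the one step touching the same carbonyl, an 8.7-fold lower number from compound 1 to compound 2 (0.94 log units; beyond the scatter), saw inhibition strengthen when hydroxy took the place of the larger group, so covering that hydroxy with methyl is expected to move the number back up. Compound 3 is therefore estimated at 30 nM, within 8 nM to 120 nM, a step of a 6.0-fold higher number from compound 2 to compound 3 (0.78 log units; beyond the scatter) toward weaker inhibition.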

Compound 3, half-maximal inhibitory concentration: 40.6 nM
Compound 3: the middle estimate sits 1.4-fold (0.13 log units) below what was measured; measured number inside the range.
By their numbers in this assay, from the lowest: compound 2; then compounds 3 and 1 (each within the scatter of the next).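

In this assay the step of an 8.1-fold higher number from compound 2 to compound 3 (0.91 log units; beyond the scatter) shows that a single methyl on this oxygen is enough to lose the low number of compound 2. The step of a 1.1-fold lower number from compound 1 to compound 3 (0.03 log units; within the scatter) puts methoxy level with 4-methylpiperazin-1-yl on the carbonyl carbon, so among these three groups only hydroxy gives the low number. No evidence at hand explains either step.

From the compounds shown here alone, whether an ethoxy or a primary amide on that carbonyl carbon would sit level with compound 3 stays open. So does whether any replacement for the carboxylic acid can match compound 2.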